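The source may report more compounds than this note shows. Statements on the series, on what has been measured and on what is new or still open speak of the compounds shown alone.

Compound 2 `COc1ccc(Cn2cc(CSC(=S)N3CCN(C(N)=O)CC3)nn2)cc1` and compound 3 `COc1ccc(Cn2cc(CSC(=S)N3CCN(C(=O)NC(C)C)CC3)nn2)cc1` share the same core; compound 3 carries isopropyl in place of hydrogen on an amide-type nitrogen. In a functional assay on MGC-803 cells (Homo sapiens) for cytotoxicity, read by MTT assay, with a stated time of 72 h (on this read-out lower numbers stand for stronger inhibition and higher numbers for weaker inhibition), compound 2 reaches only a limit of the assay, > 128000 nM, and no number is available for it. Compound 1 `CC(C)NC(=O)N1CCN(C(=S)SCc2cn(Cc3ccc(F)cc3)nn2)CC1`, which also bears the isopropylcarbamoyl group, gives 760 nM in this assay. Within the data shown here, no measured step covers this change, so the expectation rests on that comparison: the expected step of an at least 42-fold lower number from compound 2 to compound 3 (1.63 log units; beyond the scatter) points toward stronger inhibition, well beyond the scatter. Compound 3 is estimated at 3000 nM, within a range from 500 nM to 50000 nM.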

Compound 3, half-maximal inhibitory concentration: 99200 nM
Beside the measured number, compound 3's estimate is 33-fold (1.52 log units) below it, outside the stated range (above it).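

In this assay, on these data alone, isopropyl in place of hydrogen on the amide-type nitrogen gives an at least 1.2-fold lower number from compound 2 to compound 3 (0.11 log units; that floor lies within the scatter) and so shows no clear gain from this change, though its true size stays unknown because compound 2 gives only a limit: the limit of > 128000 nM in this assay, at which 1 of the 3 values shown sits. The aromatic substituent matters far more: with the isopropylcarbamoyl group kept, methoxy in place of fluoro gives a 130-fold higher number from compound 1 to compound 3 (2.12 log units; beyond the scatter) and a large loss of inhibition. As far as these compounds go, what chloro on that aromatic carbon would give stays open, as does the effect of a longer chain on the amide-type nitrogen.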